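Azepane to diethylamino on the sulfonyl propyl chain

The source may hold more compounds than are shown below. What is called first, only, known or untested is meant among the compounds shown, and "the series" means these compounds.

Measured so far in an ADME assay for permeability, using PAMPA; a higher number here means that the compound crosses the layer faster, a lower number that the compound crosses the layer more slowly
compound 1 `CC1(C)CC(c2c[nH]c3c(C(N)=O)cc(-c4ccccc4)cc23)CCS1(=O)=O`: 330 nm/s
compound 2 `NC(=O)c1cc(-c2ccccc2)cc2c(C3CCN(S(=O)(=O)CCCN4CCCCCC4)CC3)c[nH]c12`: 290 nm/s
compound 3 `CC1(C)C[C@H](c2c[nH]c3c(C(N)=O)cc(-c4ccc(F)cc4)cc23)CCS1(=O)=O`: 283 nm/s

Compound 2 at 290 nm/s stands within the scatter of both compound 1 and compound 3, so these three values form one group and no order can be read among them. Within the data shown here, no two measured compounds differ in one place only, which leaves the series without a direct step to lean on.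

Compound 4 `CCN(CC)CCCS(=O)(=O)N1CCC(c2c[nH]c3c(C(N)=O)cc(-c4ccccc4)cc23)CC1` is still unmeasured. It carries diethylamino in place of azepan-1-yl on a saturated chain carbon, three bonds along the chain from a sulfonyl sulfur. The count for that swap is diethylamino in place of azepan-1-yl on a saturated chain carbon, three bonds along the chain from a sulfonyl sulfur and nothing else in compound 2 is altered.

Compound 2 at 290 nm/s anchors the expectation, and the values of compound 1 and compound 3 stay within the scatter of it although neither carries this chain. Among the measured compounds shown here, no step beyond the scatter is expected in this assay for this swap, though no measured pair tests it directly. The estimated step is a 1.1-fold lower number from compound 2 to compound 4 (0.03 log units; within the scatter) and it stays within the scatter. For compound 4 the estimate is 270 nm/s with an expected range of 130 nm/s to 550 nm/s for a single measurement.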

Compound 4, apparent permeability: 200 nm/s
Beside the measured number, compound 4's estimate is 1.4-fold (0.13 log units) above it; low and high end bracket the measured number.
By their numbers in this assay, from the lowest: compounds 4, 3, 2 and 1 (each within the scatter of the next).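

In this assay, the series now has its first direct one-place comparison, and it reads a 1.5-fold lower number from compound 2 to compound 4 (0.16 log units; within the scatter) for diethylamino in place of azepan-1-yl on a saturated chain carbon, three bonds along the chain from a sulfonyl sulfur. The two groups cannot be told apart in this read-out, so the seven-membered non-aromatic ring is not needed at this position for a value in the same group as the rest of the series. Nothing measured here speaks to the reason for this result.

Among these compounds, whether a morpholine, a dimethylamino group or a longer chain between the sulfonyl sulfur and the amine would also stay within the scatter remains open, as the single pair covers only these two groups on a propyl chain. The same pair also cannot show whether the swap would read alike with a fluorine added to the shared core, or with a carboxylic acid in place of the amine.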